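From fluoro to sulfamoyl: an expected modest cytotoxicity shift

The compounds below may be only part of what the source reports. "The series", "measured", "known", "first", "only" and "open" are said of these compounds alone.

Of the compounds shown here, three sharing one core have been tested in an ADME assay on LLC-MK2 cells (Macaca mulatta) for cytotoxicity, read by spectrophotometry and crystal violet staining, with a stated time of 4 days; on this read-out lower numbers stand for higher toxicity in this test and higher numbers for lower toxicity in this test. Compound 1 `CC(C)n1ncc2c(C(=O)Nc3ccccc3F)cc(-c3cccs3)nc21` gives 50000 nM, compound 2 `CC(C)n1ncc2c(C(=O)Nc3cc(C(N)=O)ccc3F)cc(-c3cccs3)nc21` gives 25000 nM, and compound 3 `CC(C)n1ncc2c(C(=O)Nc3cc(F)ccc3F)cc(-c3cccs3)nc21` gives 100000 nM. Two steps place compound 3 among them: a 2.0-fold higher number from compound 1 to compound 3 (0.30 log units; within the scatter), and a 4.0-fold higher number from compound 2 to compound 3 (0.60 log units; beyond the scatter).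

Compound 4 `CC(C)n1ncc2c(C(=O)Nc3cc(S(N)(=O)=O)ccc3F)cc(-c3cccs3)nc21` has not yet been measured. It carries sulfamoyl in place of fluoro on an aromatic carbon of compound 3 (sulfamoyl in place of fluoro on an aromatic carbon). Among the measured compounds shown here, no sulfamoyl compound has a value in this assay, so the closest guide is a swap at the same place involving carbamoyl, which is a different group. That guide is a 4.0-fold higher number from compound 2 to compound 3 (0.60 log units; beyond the scatter), which is read backwards here. The other carbamoyl step, a 2.0-fold lower number from compound 1 to compound 2 (0.30 log units; within the scatter), is smaller. A similar drop from compound 3 therefore seems likely, and the expected change is a 3.3-fold lower number from compound 3 to compound 4 (0.52 log units; beyond the scatter). For compound 4 the estimated value is 30000 nM, with an expected range from 10000 nM to 80000 nM.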

Compound 4, half-maximal cytotoxic concentration: 25000 nM
Beside the measured number, compound 4's estimate is 1.2-fold (0.08 log units) above it; the measured number falls inside the stated range.
By their numbers in this assay, from the lowest: compounds 2, 4, 1 and 3 (each within the scatter of the next, the first and the last beyond it).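

In this assay, sulfamoyl in place of fluoro gives a 4.0-fold lower number from compound 3 to compound 4 (0.60 log units; beyond the scatter), so the drop first seen with carbamoyl at this place also appears with a second, larger group. The two groups cannot be told apart here, with no change at the digits printed from compound 2 to compound 4 (within the scatter), and sulfamoyl in place of hydrogen gives only a 2.0-fold lower number from compound 1 to compound 4 (0.30 log units; within the scatter), so the shifts beyond the scatter at this place are those that start from compound 3 and lead to compound 2 or compound 4. Nothing available here explains why the numbers shift.

As far as these compounds go, whether an amine or a carboxylic acid at this place would give a number close to those of compound 2 and compound 4 remains open. So does whether sulfamoyl would give a similar step on a different part of the shared core.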